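This account rests on a few compounds, and the source may have more. Where it says the series, first, only, none or still open, it means among the compounds named here.

Of the compounds shown here, three built on one shared core have been measured so far. In a functional assay on CWR22R cells (Homo sapiens) for antiproliferative activity, read by propidium iodide staining, with a stated time of 96 h (a lower number here means a stronger inhibitor, a higher number a weaker inhibitor), compound 1 `CC(O)(CSc1ccc(OC(F)(F)F)cc1)C(=O)Nc1cccc(S(F)(F)(F)(F)F)c1` gives 17000 nM, compound 2 `CC(O)(CSc1cc(C(F)(F)F)cc(C(F)(F)F)c1)C(=O)Nc1cccc(S(F)(F)(F)(F)F)c1` gives 4400 nM, and compound 3 `CC(O)(COc1ccc(S(F)(F)(F)(F)F)cc1)C(=O)Nc1cccc(S(F)(F)(F)(F)F)c1` gives 10200 nM. Compound 3 therefore lies within the usual scatter of compound 1, so these two cannot be told apart, while compound 2 reads lower than compound 3 by more than the scatter.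

The next molecule, compound 4 `CC(O)(COc1ccc(OC(F)(F)F)cc1)C(=O)Nc1cccc(S(F)(F)(F)(F)F)c1`, differs from compound 3 in one place: a group of 5 heavy atoms (1 carbon, 1 oxygen, 3 fluorine; no ring) in place of a group of 6 heavy atoms (5 fluorine, 1 sulfur; no ring), on an aromatic carbon. The swap sits on an aromatic carbon of a six-membered aromatic ring of carbon only, para to a large group, and trifluoromethoxy is the group that enters.

Among the compounds with values here, no two measured compounds differ in just one place, so the data give no direct measure of a swap like this. The nearest clue is compound 1, which also carries trifluoromethoxy and stands at 17000 nM, within the scatter of compound 3. On that basis, no change beyond the scatter is expected in this assay, and any drift would probably be towards a somewhat higher number. The expected step, a 1.3-fold higher number from compound 3 to compound 4 (0.11 log units; within the scatter), stays within the scatter. The estimated value for compound 4 is 13000 nM, with an expected range from 6500 nM to 26000 nM.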

Compound 4, half-maximal inhibitory concentration: 12900 nM
Compound 4: middle estimate off by 1.0-fold (0.00 log units), on the high side, and the stated range covers the measured number.
By their numbers in this assay, from the lowest: compound 2; then compounds 3, 4 and 1 (each within the scatter of the next).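

In this assay, within the data shown here, the swap of the group of five fluorine atoms and one sulfur atom for trifluoromethoxy gives the first direct one-place comparison: a 1.3-fold higher number from compound 3 to compound 4 (0.10 log units; within the scatter). The two compounds therefore cannot be told apart, so on this aromatic carbon either group goes with the same reading, even though the two groups differ in heavy atoms and in their count of hydrogen-bond acceptors. No measurement is available to explain why these two groups read alike.

The compounds shown leave open how a quite different group on this aromatic carbon, such as an amine, a carboxylic acid or a longer alkyl chain, would read, since a result for two fluorine-bearing groups says little about groups of another kind. They also leave open whether this same swap would again stay within the scatter if sulfur, rather than oxygen, linked this ring to the rest of the molecule.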